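The compounds below may be only part of what the source reports. "The series", "measured", "known", "first", "only" and "open" are said of these compounds alone.

Compound 1 `CON/C(=N\C1=NC(=O)C(=O)N1C(C)C)Nc1ccc(Cl)c(Cl)c1`, compound 2 `C=CCON/C(=N\C1=NC(=O)C(=O)N1C(C)C)Nc1ccc(Cl)c(Cl)c1` and compound 3 `CC(C)N/C(=N\C1=NC(=O)C(=O)N1C(C)C)Nc1ccc(Cl)c(Cl)c1` share one core and differ only on an amine nitrogen. In an in vitro ADME assay on microsomes from liver (Homo sapiens) for metabolic stability, read by LC-MS (a lower number here means that the compound disappears faster, a higher number that the compound lasts longer), compound 1 gives > 1 h, which is a limit of the assay and not a number. Compound 2 likewise reaches only the limit > 1 h in this assay. Compound 3 also sits at the limit > 1 h in this assay. All three values therefore rest at the limit of > 1 h in this assay, at which 3 of the 3 values shown sit, and compound 1 stands no higher or lower than the others on what is shown.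

Compound 4 `CC(C)N1C(=O)C(=O)N=C1/N=C(\NCCCCN1CCCC1)Nc1ccc(Cl)c(Cl)c1` has not been measured in this assay. Against compound 1 the change is 4-(pyrrolidin-1-yl)butyl in place of methoxy on an amine nitrogen.

The steps that could bear on this change, a step that the two limits leave unreadable from compound 1 to compound 2, a step that the two limits leave unreadable from compound 1 to compound 3 and a step that the two limits leave unreadable from compound 2 to compound 3, are all unreadable, since both ends of each sit at the limit. They show only that replacing the methoxy on the amine nitrogen by allyloxy or isopropyl leaves the half-life at the limit; they give no size or direction. Within the data shown here, for the larger 4-(pyrrolidin-1-yl)butyl the account has no comparable step, so the expected size of an at least 1.2-fold lower number from compound 1 to compound 4 (0.09 log units; that floor lies within the scatter) is uncertain. Compound 4 is estimated at 0.8 h, within 0.25 h to 2.5 h.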

Compound 4, half-life: > 1 h
Compound 4 was reported as a limit (the forecaster's own chance of this, stated with the estimate: 40%); middle value at least 1.2-fold (0.09 log units) away from the limit.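

In this assay compound 4 gives > 1 h, which is a limit of the assay and not a number. The steps from compounds 1, 2 and 3 to compound 4 therefore cannot be read, since all four values rest at one limit: the limit of > 1 h in this assay, at which 4 of the 4 values shown sit.

The compounds shown leave open how long any of them actually lasts, and whether exchanging the group on the amine nitrogen alters the half-life at all.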